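Aryl to Dimethylisoxazole on the Sulfonamide

A few compounds are considered here, and "the series" means these few. Any claim that something is new, unique, unknown or untested is made for them only; others in the source may bear on it.

The measured compounds and their values:
compound 1 `Nc1ncnc(N2CC[C@@]3(CCCN(C[C@H](O)CNS(=O)(=O)c4ccccc4F)C3)C2)c1C1CC1`, 81 nM;
compound 2 `Cc1ccc(S(=O)(=O)NC[C@@H](O)CN2CCC[C@@]3(CCN(c4ncnc(N)c4C4CC4)C3)C2)c(C)c1`, 160 nM.

In an assay on isolated protein for inhibition of RAC-alpha serine/threonine-protein kinase (Homo sapiens) (a higher number here means a weaker inhibitor, a lower number a stronger inhibitor), compound 1 gives 81 nM. In this assay, among the compounds with values here, compound 2 gives 160 nM, the higher of the two numbers, though the one step recorded, a 2.0-fold higher number from compound 1 to compound 2 (0.30 log units; within the scatter), lies within the scatter, so the two compounds cannot be ordered on these data.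

Compound 3 `Cc1noc(C)c1S(=O)(=O)NC[C@@H](O)CN1CCC[C@@]2(CCN(c3ncnc(N)c3C3CC3)C2)C1` has not been measured in this assay. It differs from compound 2 in one place: 3,5-dimethyl-1,2-oxazol-4-yl in place of 2,4-dimethylphenyl on a sulfonyl sulfur. Within the data shown here, the only step that bears on it is the exchange of one aryl group for another at the same sulfonyl sulfur, a 2.0-fold higher number from compound 1 to compound 2 (0.30 log units; within the scatter), which stayed within the scatter. Among the measured compounds shown here, a five-membered aromatic ring with two hetero atoms is a larger departure than that step, and no measured pair shows such a change, so the expectation carries more uncertainty than the earlier step. On balance the step from compound 2 to compound 3 is expected to be small, a 1.3-fold higher number from compound 2 to compound 3 (0.10 log units; within the scatter), with no clear direction beyond the scatter. The estimate for compound 3 in this assay is therefore 200 nM, within a range from 70 nM to 600 nM.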

Compound 3, half-maximal inhibitory concentration: 3 nM
For compound 3 the middle estimate is 67-fold (1.82 log units) above the measured one, outside the stated range (below it).
By their numbers in this assay, from the lowest: compound 3; then compounds 1 and 2 (each within the scatter of the next).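

At this sulfonyl sulfur, the nature of the ring proved to matter far more than the earlier exchange between two six-membered aromatic rings of carbon only could show: in this assay, the 3,5-dimethyl-1,2-oxazol-4-yl group gives a 53-fold lower number from compound 2 to compound 3 (1.73 log units; beyond the scatter) and a 27-fold lower number from compound 1 to compound 3 (1.43 log units; beyond the scatter), both beyond the scatter. The position therefore responds strongly to at least this one change, which brings in a five-membered aromatic ring with 2 hetero atoms and 2 hydrogen-bond acceptors in place of a group with 0 hydrogen-bond acceptors. No measurement is available that explains the size of this step.

The compounds leave open whether the ring nitrogen and oxygen or the two methyl groups carry the step, a question that the unsubstituted 1,2-oxazol-4-yl group or a 3-methyl-1,2-oxazol-4-yl group would address. On these data alone, it also remains open whether the step is particular to this ring or would extend to other five-membered aromatic rings at the same sulfur, such as a 1,3-dimethylpyrazol-4-yl or a thiophene ring.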